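Swapping Methyl for Bromo on a Serotonin Receptor Antagonist

The source may hold more compounds than are shown below. What is called first, only, known or untested is meant among the compounds shown, and "the series" means these compounds.

Compound 1 `Cc1cccc(N2CCN(C3CN4CCC3CC4)C2=O)c1` has been tested in a functional assay (Cavia porcellus) for antagonist activity at Serotonin 3 (5-HT3) receptor (Homo sapiens) (a lower number here means a stronger inhibitor, a higher number a weaker inhibitor), where compound 1 gives 12 nM. Among the measured compounds shown here, that is the lowest of the two numbers known so far. The other measured compound, compound 2 `O=C1N(c2cc(Cl)cc(Cl)c2)CCN1C1CN2CCC1CC2`, carries two chloro groups on its aromatic ring, and in this assay compound 2 gives 45 nM, a higher number, with a gap to compound 1 that lies beyond the usual scatter of repeated measurements.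

Compound 3 `O=C1N(c2cccc(Br)c2)CCN1C1CN2CCC1CC2` differs from compound 1 in one place only: bromo in place of methyl on an aromatic carbon. For the measured compounds named here, no pair of measured compounds shows this particular swap, so its effect cannot be read off directly. Both groups that trade places are single heavy atoms with no donors or acceptors, so the step is expected to be a 1.3-fold higher number from compound 1 to compound 3 (0.10 log units; within the scatter), small and without a clear direction beyond the scatter. Compound 3 is therefore estimated at 15 nM, with a range from 5 nM to 45 nM.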

Compound 3, antagonist equilibrium constant: 38.3 nM
Compound 3: middle estimate off by 2.6-fold (0.41 log units), on the low side; low and high end bracket the measured number.
By their numbers in this assay, from the lowest: compound 1; then compounds 3 and 2 (each within the scatter of the next).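

Trading methyl for bromo on this aromatic carbon gives a 3.2-fold higher number from compound 1 to compound 3 (0.50 log units; beyond the scatter) in this assay and so shows, in a direct comparison, that the position is sensitive to this change. The two groups match in what can be counted, each being a single heavy atom with no hydrogen-bond donors or acceptors, yet the step lies beyond the usual scatter, with the 3-methylphenyl compound giving the lower number. No measurement available here accounts for the difference between the two groups.

The compounds shown leave open how groups such as fluoro, methoxy or an amine would rank on this same carbon. They also leave open whether the same swap would give a step of similar size on a different core.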